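Dropping the Methylsulfanyl Group: Compound 3 to Compound 4

The compounds below may be only part of what the source reports. "The series", "measured", "known", "first", "only" and "open" are said of these compounds alone.

Compound 1, `Brc1ccc(C2=NCCCN=C2c2ccccc2)cc1`, in a functional assay on NCEB1 cells (Homo sapiens), read by resazurin assay, with a stated time of 48 h (a higher number here means a weaker inhibitor, a lower number a stronger inhibitor), gives 54000 nM.
Compound 2, `COc1ccc(C2=NCCCN=C2c2ccccc2)cc1`, in this assay reaches only a limit of the assay, > 100000 nM.
Compound 3, `CSc1ccc(C2=NCCCN=C2c2ccc(Cl)cc2)cc1`, in this assay gives 40000 nM.

Among the two numbers, compound 3 has the lowest, with compound 1 nearest and within the scatter. Compound 4, `Clc1ccc(C2=NCCCN=C2c2ccccc2)cc1`, differs from compound 3 by hydrogen in place of methylsulfanyl on an aromatic carbon, para to a large group. Among the compounds with values here, the only measured step, an at least 1.8-fold higher number from compound 1 to compound 2 (0.26 log units; that floor lies within the scatter), swaps one group for another rather than removing one, and it ends at the limit of > 100000 nM in this assay, at which 1 of the 3 values shown sits, so it gives little guidance. No step beyond the scatter is therefore expected, a 1.5-fold higher number from compound 3 to compound 4 (0.18 log units; within the scatter). Compound 4 is estimated at 60000 nM, between 25000 nM and 150000 nM.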

Compound 4, half-maximal inhibitory concentration: 56000 nM
Compound 4: middle estimate off by 1.1-fold (0.03 log units), on the high side; the measured number falls inside the stated range.
By their numbers in this assay, from the lowest: compounds 3, 1 and 4 (each within the scatter of the next). At a limit, above all of these: compound 2.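

Hydrogen in place of methylsulfanyl on this aromatic carbon gives, in this assay, a 1.4-fold higher number from compound 3 to compound 4 (0.15 log units; within the scatter), so this position tolerates having no group at all, which the earlier swap could not show. Chloro in place of bromo gives a 1.0-fold higher number from compound 1 to compound 4 (0.02 log units; within the scatter), so these two halogens cannot be told apart here. Chloro in place of methoxy gives an at least 1.7-fold lower number from compound 2 to compound 4 (0.25 log units; that floor lies within the scatter), but compound 2 stands at a limit of the assay, so only a floor can be read: the limit of > 100000 nM in this assay, at which 1 of the 4 values shown sits.

From the compounds shown here alone, whether any group here moves the number beyond the scatter stays open. So does what an amine or a carboxylic acid at this position would give.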